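Benzyl substituent swap in the indole hydrazone series

The source may report more compounds than this note shows. Statements on the series, on what has been measured and on what is new or still open speak of the compounds shown alone.

Measured so far:
compound 1, `COc1ccc(Cn2cc(/C=N\NC(=O)c3cn(C)c4ccccc34)c3ccc(F)cc32)cc1`, 22600 nM
compound 2, `O=C(N/N=C\c1cn(Cc2ccc(Cl)cc2)c2cc(F)ccc12)c1c[nH]c2ccc(Br)cc12`, 8300 nM

In a functional assay on MCF7 cells (Homo sapiens) for cytotoxicity (a higher number here means a weaker inhibitor, a lower number a stronger inhibitor), compound 1 gives 22600 nM and compound 2 gives 8300 nM. Compound 2 holds the lower of the two numbers, and its gap to compound 1 lies beyond the scatter. Compound 3 `COc1ccc(Cn2cc(/C=N\NC(=O)c3c[nH]c4ccc(Br)cc34)c3ccc(F)cc32)cc1` has not yet been measured. It differs from compound 2 in one place: methoxy in place of chloro on an aromatic carbon. Among the compounds with values here, no measured pair differs only in this place, so the size of this change cannot be read from the series; compound 1 also carries 4-methoxybenzyl, but it differs from compound 2 in further places, so its value gives no clean reading of the swap. A step of modest size toward a weaker value is expected, a 1.6-fold higher number from compound 2 to compound 3 (0.19 log units; within the scatter), with a result within the scatter of the starting point also plausible. Compound 3 is expected at 13000 nM, within 5000 nM to 35000 nM.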

Compound 3, half-maximal inhibitory concentration: 31700 nM
For compound 3 the middle estimate is 2.4-fold (0.39 log units) below the measured one; measured number inside the range.
By their numbers in this assay, from the lowest: compound 2; then compounds 1 and 3 (each within the scatter of the next).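

In this assay, within the data shown here, methoxy in place of chloro on the benzyl group gives a 3.8-fold higher number from compound 2 to compound 3 (0.58 log units; beyond the scatter) and provides the first clean reading of this position, with 4-chlorobenzyl giving the lower number against the 5-bromo-1H-indol-3-yl partner. With 4-methoxybenzyl held constant, 5-bromo-1H-indol-3-yl in place of 1-methyl-1H-indol-3-yl gives a 1.4-fold higher number from compound 1 to compound 3 (0.15 log units; within the scatter) and therefore does not separate the two acyl groups. No measured data available here explain the size of the benzyl step.

Still open, going by these compounds, is whether the chloro to methoxy step holds with the 1-methyl-1H-indol-3-yl partner. On these data alone, how a fluoro, a trifluoromethyl, a nitrile or a dimethylamino group would compare at this same place on the benzyl ring also remains unknown.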